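The compounds below may be only part of what the source reports. "The series", "measured", "known", "first", "only" and "open" are said of these compounds alone.

Among the measured compounds shown here, compound 3 `CN(C)CCn1cnnc1-c1cc(Oc2ccc(NC(=O)N/N=C/c3cccc(O)c3)cc2F)ccn1` stands second highest of the three numbers known in a functional assay on NCI-H460 cells (Homo sapiens) for cytotoxicity, read by MTT assay, with a stated time of 72 h (a lower number here means a stronger inhibitor, a higher number a weaker inhibitor), where compound 3 gives 780 nM. Its nearest neighbour is compound 2 `CN(C)CCn1cnnc1-c1cc(Oc2ccc(NC(=O)N/N=C/c3cccc(Br)c3)cc2F)ccn1`, which gives 520 nM; the step of a 1.5-fold higher number from compound 2 to compound 3 (0.18 log units; within the scatter) lies within the scatter. Further away is compound 1 `COc1ccc(OC)c(/C=N/NC(=O)Nc2ccc(Oc3ccnc(-c4nncn4CCN(C)C)c3)c(F)c2)c1`, which gives 2930 nM; the steps of a 5.6-fold lower number from compound 1 to compound 2 (0.75 log units; beyond the scatter) and a 3.8-fold lower number from compound 1 to compound 3 (0.57 log units; beyond the scatter) both lie beyond the scatter. Compound 4 `CN(C)CCn1cnnc1-c1cc(Oc2ccc(NC(=O)N/N=C/c3ccc(F)cc3Cl)cc2F)ccn1` has not yet been measured. It differs from compound 3 in one place: 2-chloro-4-fluorophenyl in place of 3-hydroxyphenyl on a carbon with a double bond to nitrogen. Of the measured steps, a 1.5-fold higher number from compound 2 to compound 3 (0.18 log units; within the scatter) is the one that bears on this change, a hydroxy exchanged for a halogen on the same ring, and it stayed within the scatter. A halogenated phenyl on this carbon is thus known only from compound 2, whose value in this assay is the guide. Compound 4 is expected to sit close to that, a step that may not exceed the scatter, a 1.4-fold lower number from compound 3 to compound 4 (0.15 log units; within the scatter). The estimate for compound 4 in this assay is 550 nM, with a range from 200 nM to 1500 nM.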

Compound 4, half-maximal inhibitory concentration: 720 nM
Estimate against measurement, compound 4: 1.3-fold (0.12 log units) below; low and high end bracket the measured number.
By their numbers in this assay, from the lowest: compounds 2, 4 and 3 (each within the scatter of the next); then compound 1.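

In this assay, 2-chloro-4-fluorophenyl on the carbon with a double bond to nitrogen cannot be told apart from 3-hydroxyphenyl (a 1.1-fold lower number from compound 3 to compound 4 (0.03 log units; within the scatter)) or from 3-bromophenyl (a 1.4-fold higher number from compound 2 to compound 4 (0.14 log units; within the scatter)), so a ring with no hydrogen-bond donor reads the same here as the ring that has one. Only the 2,5-dimethoxyphenyl ring stands apart (a 4.1-fold lower number from compound 1 to compound 4 (0.61 log units; beyond the scatter)), which makes compound 1 the one exception to an otherwise flat set of four. Nothing available here accounts for that gap.

The compounds shown leave open what an unsubstituted phenyl, or a ring bearing a single methoxy, an amine or a carboxylic acid, would give on this carbon. They also leave open whether a longer alkyl chain could take the place of the ring.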